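The source may hold more compounds than are shown below. What is called first, only, known or untested is meant among the compounds shown, and "the series" means these compounds.

Measured so far in a functional assay on SK-OV-3 cells (Homo sapiens) for cytotoxicity, read by spectrophotometry, with a stated time of 72 h; on this read-out higher numbers stand for weaker inhibition and lower numbers for stronger inhibition:
compound 1 `COc1ccc(-c2cccc(=O)n2-c2cc(OC)c(OC)c(OC)c2)cc1` — < 10 nM
compound 2 `COc1cc(-n2c(-c3ccc([N+](=O)[O-])cc3)cccc2=O)cc(OC)c1OC` — 201 nM
compound 3 `COc1ccc(-n2c(-c3cc(OC)c(OC)c(OC)c3)cccc2=O)cc1` — 1540 nM

The value of compound 1 is a limit of this assay, not a number (the limit of < 10 nM in this assay, at which 1 of the 3 values shown sits). Compound 2 carries nitro in place of methoxy on an aromatic carbon relative to compound 1, and the step is an at least 20-fold higher number from compound 1 to compound 2 (1.30 log units; beyond the scatter). Compound 3 is built from the same atoms as compound 1, joined differently; the difference between the two cores is not broken down here. Compound 3 gives the highest number of the two compounds with a reported number, and compound 2 sits nearest to it.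

Compound 4 `COc1cc(-c2cccc(=O)n2-c2ccc([N+](=O)[O-])cc2)cc(OC)c1OC` is not yet measured in this assay. It differs from compound 3 by nitro in place of methoxy on an aromatic carbon, the same change that separates compound 2 from compound 1, made on the same place. On the strength of that single measured step, the change from compound 3 to compound 4 is expected to raise the number again, though the core of compound 3 is the weaker of the two cores and the step in this assay is estimated at a 9.7-fold higher number from compound 3 to compound 4 (0.99 log units; beyond the scatter). Compound 4 is expected to come out near 15000 nM, with a likely span from 3000 nM to 80000 nM.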

Compound 4, half-maximal inhibitory concentration: 311 nM
Beside the measured number, compound 4's estimate is 48-fold (1.68 log units) above it, and the stated range ends above it.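

In this assay, nitro in place of methoxy gives a 5.0-fold lower number from compound 3 to compound 4 (0.69 log units; beyond the scatter), so the direction of this change does not carry from the core of compound 3 to the core of compound 1, and the two steps differ: the same change on two cores in this assay, an at least 20-fold higher number (1.30 log units; beyond the scatter) from compound 1 to compound 2 and a 5.0-fold lower number (0.69 log units; beyond the scatter) from compound 3 to compound 4, at least 99-fold (1.99 log units) apart, beyond the scatter of two such steps

Compound 1 gives < 10 nM, which is a limit of this assay and not a number, so the earlier step and the gap between the two steps are bounds and not exact sizes: the limit of < 10 nM in this assay, at which 1 of the 4 values shown sits.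

With a single pair on each core, the result shows that the effect of this change depends on the core, but it gives neither the cause of the reversal nor a rule for other groups.

Open, as far as these compounds go, is whether an amine or a carboxylic acid at this place, para to a large group, would also move in opposite directions on the two cores. Also open, from the compounds shown here alone, is whether a longer chain in place of methoxy would follow either of the two steps.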